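A few compounds are considered here, and "the series" means these few. Any claim that something is new, unique, unknown or untested is made for them only; others in the source may bear on it.

Measured in an assay on cells for displacement of a labelled ligand from corticotropin-releasing factor receptor 1 (Homo sapiens), with a stated time of 100 min; a higher number here means a weaker inhibitor, a lower number a stronger inhibitor:
compound 1 `Cc1cc(C)c(-n2c(Cl)cn3c(CN(CCC(F)(F)F)CC4CC4)c(C(F)(F)F)nc23)c(C)c1` — 16 nM
compound 2 `Cc1cc(C)c(-n2c(Cl)cn3c(CN(CCC(F)(F)F)Cc4cccc(F)c4)c(C(F)(F)F)nc23)c(C)c1` — 49 nM
compound 3 `Cc1cc(C)c(-n2c(Cl)cn3c(CN(CCC(F)(F)F)Cc4ccc(F)cc4)c(C(F)(F)F)nc23)c(C)c1` — 34 nM

Compound 3 has the second highest number of the three; it is within the scatter of compound 2, a 1.4-fold lower number from compound 2 to compound 3 (0.16 log units; within the scatter), yet beyond it from compound 1, a 2.1-fold higher number from compound 1 to compound 3 (0.33 log units; beyond the scatter). Compound 4 `Cc1cc(C)c(-n2c(Cl)cn3c(CN(CCC(F)(F)F)Cc4ccc(Cl)cc4)c(C(F)(F)F)nc23)c(C)c1` differs from compound 3 by chloro in place of fluoro on an aromatic carbon. For the measured compounds named here, no measured step swaps one halogen for another on that ring; the steps of a 3.1-fold higher number from compound 1 to compound 2 (0.49 log units; beyond the scatter) and a 2.1-fold higher number from compound 1 to compound 3 (0.33 log units; beyond the scatter) exchanged cyclopropyl for a fluorophenyl and were modest, while the exchange of 3-fluorophenyl for 4-fluorophenyl stayed within the scatter. Since the benzyl is kept, compound 4 is expected to show no step beyond the scatter, a 1.1-fold lower number from compound 3 to compound 4 (0.05 log units; within the scatter). Compound 4 is estimated at 30 nM, between 12 nM and 75 nM.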

Compound 4, inhibition constant: 12 nM
Estimate against measurement, compound 4: 2.5-fold (0.40 log units) above; low and high end bracket the measured number.
By their numbers in this assay, from the lowest: compounds 4 and 1 (each within the scatter of the next); then compounds 3 and 2 (each within the scatter of the next).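

In this assay, the halogen on the benzyl ring counts for more than the earlier fluoro exchange suggested: chloro in place of fluoro, para to a large group, gives a 2.8-fold lower number from compound 3 to compound 4 (0.45 log units; beyond the scatter), and the 4-chlorophenyl in place of 3-fluorophenyl gives a 4.1-fold lower number from compound 2 to compound 4 (0.61 log units; beyond the scatter). A benzyl need not cost anything against cyclopropyl, since 4-chlorophenyl in its place gives a 1.3-fold lower number from compound 1 to compound 4 (0.12 log units; within the scatter). Nothing available here accounts for the difference between chloro and fluoro. Going by these compounds, whether a bromo, methyl or methoxy group on that same aromatic carbon would lower the number further stays open.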